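A few compounds are considered here, and "the series" means these few. Any claim that something is new, unique, unknown or untested is made for them only; others in the source may bear on it.

Measured in a functional assay on DU-145 cells (Homo sapiens) for antiproliferative activity, read by MTT assay, with a stated time of 48 h; on this read-out higher numbers stand for weaker inhibition and lower numbers for stronger inhibition:
- compound 1 `C/C(=C\CC/C(C)=C/CC[C@@H]1[C@@]2(C)CCC(=O)C(C)(C)[C@H]2CC[C@@]1(C)O)CC/C=C(\C)C(=O)OCc1cn(C[C@@H]2O[C@H](n3ccc(=O)[nH]c3=O)C[C@H]2O)nn1`: 33100 nM
- compound 2 `C/C(=C\CC/C(C)=C/CC[C@@H]1[C@@]2(C)CCC(=O)C(C)(C)[C@H]2CC[C@@]1(C)O)CC/C=C(\C)C(=O)OCc1cn(-c2cccc([N+](=O)[O-])c2)nn1`: > 150000 nM, a limit and not a number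
- compound 3 `COc1ccc(-n2cc(COC(=O)/C(C)=C/CC/C(C)=C/CC/C(C)=C/CC[C@@H]3[C@@]4(C)CCC(=O)C(C)(C)[C@H]4CC[C@@]3(C)O)nn2)cc1`: 135000 nM

Compound 2 stands only at a limit: the limit of > 150000 nM in this assay, at which 1 of the 3 values shown sits. Compound 4 `C/C(=C\CC/C(C)=C/CC[C@@H]1[C@@]2(C)CCC(=O)C(C)(C)[C@H]2CC[C@@]1(C)O)CC/C=C(\C)C(=O)OCc1cn(-c2ccccc2)nn1` has hydrogen in place of nitro on an aromatic carbon, meta to a large group, (hydrogen in place of nitro on an aromatic carbon); cut one bond further out, this is 3-nitrophenyl to phenyl. Among the measured compounds shown here, the one measured step that bears on it replaces the same 3-nitrophenyl with 4-methoxyphenyl: an at least 1.1-fold lower number from compound 2 to compound 3 (0.04 log units; that floor lies within the scatter). For the measured compounds named here, no measured step links compound 1 to compound 4. On that basis, only a small move to a lower number is expected in this assay, possibly none beyond the scatter. The expected change is an at least 1.1-fold lower number from compound 2 to compound 4 (0.06 log units; that floor lies within the scatter). Compound 4 is estimated at 130000 nM, with an expected range of 60000 nM to 200000 nM.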

Compound 4, half-maximal inhibitory concentration: 95500 nM
The estimate for compound 4 lay 1.4-fold (0.13 log units) above the measured number; the range from low to high includes it.
By their numbers in this assay, from the lowest: compound 1; then compounds 4 and 3 (each within the scatter of the next). At a limit, above all of these: compound 2.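

The phenyl group gives the series a reference without a substituent: in this assay, a 1.4-fold lower number from compound 3 to compound 4 (0.15 log units; within the scatter). The nitro end of this comparison is a limit and not a number, so the step reads only as a floor, an at least 1.5-fold lower number from compound 2 to compound 4 (0.19 log units; that floor lies within the scatter), and leaves the true size of the nitro change unresolved: the limit of > 150000 nM in this assay, at which 1 of the 4 values shown sits. No substituent on this phenyl has yet shown a step beyond the scatter.

From the compounds shown here alone, whether an amine or a carboxylic acid on this aromatic carbon would give such a step remains open.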